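Anilinoquinazoline-type series: cytotoxicity in cultured leukaemia cells

The source may report more compounds than this note shows. Statements on the series, on what has been measured and on what is new or still open speak of the compounds shown alone.

Measured compounds:
- compound 1, `COc1ccccc1Nc1nc(-c2cccc(F)c2)nc2ccc(F)cc12`, gives > 50000 nM in a functional assay on HL-60 cells (Homo sapiens) for cytotoxicity, read by MTT assay, with a stated time of 48 h; a lower number here means a stronger inhibitor, a higher number a weaker inhibitor; this is a limit of the assay, not a number.
- compound 2, `Oc1ccccc1Nc1nc(-c2cccc(F)c2)nc2ccc(F)cc12`, gives 44400 nM in this assay.

Compound 1 stands only at a limit of this assay; where it would fall on a number scale is not known, as the limit of > 50000 nM in this assay, at which 1 of the 2 values shown sits, states. Going by the values given here, the single measured step, hydrogen in place of methyl on an oxygen on an aromatic ring, reads an at least 1.1-fold lower number from compound 1 to compound 2 (0.05 log units; that floor lies within the scatter) and tells nothing beyond the scatter.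

Compound 3, `Cc1ccc(Nc2nc(-c3cccc(F)c3)nc3ccc(F)cc23)cc1`, differs from compound 1 by 4-methylphenyl in place of 2-methoxyphenyl on a nitrogen on an aromatic ring. Among the compounds with values here, no measured step touches this change, since the one step known alters the oxygen substituent and leaves the ring position untouched. With compound 1 itself sitting at the limit, there is no footing for any direction. Compound 3 is therefore expected to stay in the weak range, with an estimated step of a number no higher from compound 1 to compound 3 (the limit leaves the size open) of no size beyond the scatter. The estimate for compound 3 in this assay is 50000 nM, in the range 15000 nM to 150000 nM, and a limit rather than a number is judged about as likely as not.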

Compound 3, half-maximal inhibitory concentration: > 50000 nM
Compound 3 gave a limit, no number; the forecaster's own chance of this, stated with the estimate: 55%; the middle value lies on the limit itself.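

In this assay compound 3 gives > 50000 nM, which is a limit and not a number. The change of 2-hydroxyphenyl to 4-methylphenyl on the nitrogen reads an at least 1.1-fold higher number from compound 2 to compound 3 (0.05 log units; that floor lies within the scatter), so it shows nothing beyond the scatter, and the step from 2-methoxyphenyl to 4-methylphenyl cannot be read at all. What is new is that an aryl group on this nitrogen carrying no oxygen, with its substituent named at a different ring position, also gives no value clearly apart from the others, and the set now sits mostly at the limit: the limit of > 50000 nM in this assay, at which 2 of the 3 values shown sit.

Open, from the compounds shown here alone, is whether a carboxylic acid or a dimethylamino group in place of the methyl of 4-methylphenyl would give a number clearly apart from these three compounds. Also open, going by these compounds, is whether any change on the shared core, rather than on this nitrogen, would move the values in this assay beyond the scatter.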